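Aryl hydrazone variation on the shared core: compound 3

The compounds below may be only part of what the source reports. "The series", "measured", "known", "first", "only" and "open" are said of these compounds alone.

Compound 1 `Cn1c(=O)c(=O)n(C2CCCC2)c2nc(N/N=C/c3ccc(F)cc3Cl)ncc21` and compound 2 `Cn1c(=O)c(=O)n(C2CCCC2)c2nc(N/N=C/c3ccc(O)c(Br)c3)ncc21` share one core and differ only in the aryl group on the carbon with a double bond to nitrogen. In a functional assay on PC-3 cells (Homo sapiens) for antiproliferative activity, read by MTT assay (on this read-out higher numbers stand for weaker inhibition and lower numbers for stronger inhibition), compound 1 gives 15200 nM, and compound 2 gives 11600 nM. The step of a 1.3-fold lower number from compound 1 to compound 2 (0.12 log units; within the scatter) means that compound 2 stands with the lower of the two numbers, but the gap to compound 1 is within the scatter, so no order between them can be read. Compound 3 `Cn1c(=O)c(=O)n(C2CCCC2)c2nc(N/N=C/c3cc([N+](=O)[O-])ccc3Cl)ncc21` carries the change (2-chloro-5-nitrophenyl in place of 3-bromo-4-hydroxyphenyl on a carbon with a double bond to nitrogen). Within the data shown here, the only measured step that bears on an aryl exchange at this position is a 1.3-fold lower number from compound 1 to compound 2 (0.12 log units; within the scatter), and it was within the scatter; a third aryl variant is therefore expected to give a step of similar size, direction undecided, and is estimated at a 1.1-fold higher number from compound 2 to compound 3 (0.05 log units; within the scatter). On this basis compound 3 is expected to give 13000 nM, with a range from 5000 nM to 35000 nM.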

Compound 3, half-maximal inhibitory concentration: 9260 nM
Compound 3: middle estimate off by 1.4-fold (0.15 log units), on the high side, within the range that was stated.
By their numbers in this assay, from the lowest: compounds 3, 2 and 1 (each within the scatter of the next).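

In this assay, replacing the 3-bromo-4-hydroxyphenyl group with 2-chloro-5-nitrophenyl gives a 1.3-fold lower number from compound 2 to compound 3 (0.10 log units; within the scatter), and replacing 2-chloro-4-fluorophenyl with the same group gives a 1.6-fold lower number from compound 1 to compound 3 (0.22 log units; within the scatter), so all three aryl groups on this carbon now lie within the scatter of one another. The exchange from compound 2 to compound 3 removes the hydroxyl group with its hydrogen-bond donor and brings in a nitro group, yet it produces no readable step, so neither group separates from the others on this read-out. No evidence is available to explain the closeness of these numbers.

From the compounds shown here alone, all three aryl groups carry a halogen, so it remains open whether a phenyl bearing only a carboxylic acid or an amine would move the number beyond the scatter. The compounds shown also leave open whether any change away from this carbon would do so.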